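Chloro for Methyl Next to the Ring Nitrogen

The source may report more compounds than this note shows. Statements on the series, on what has been measured and on what is new or still open speak of the compounds shown alone.

Measured compounds:
compound 1 `Cc1cccnc1-c1nc2ccccc2[nH]1`: 17%
compound 2 `Cc1ccnc(-c2nc3ccccc3[nH]2)c1`: -4%
compound 3 `Cc1cccc(-c2nc3ccccc3[nH]2)n1`: 44%

All three were tested in a functional assay on the whole organism with Rattus norvegicus as the target, read by paw edema, with a stated time of 3 h, at a dose of 100 mg/kg by the oral route; on this read-out higher numbers stand for more inhibition at the one dose given (going by the name of the read-out) and lower numbers for less inhibition. Compound 3 gives the highest number of the three, 44%; its distance to compound 1 and to compound 2 lies beyond the usual scatter in each case, so compound 3 stands clearly above the other two. For the measured compounds named here, the three share one core and differ only in where a methyl sits on the six-membered aromatic ring with one nitrogen, yet no pair of them differs in a single place in a way that gives a counted step.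

Compound 4 `Clc1cccc(-c2nc3ccccc3[nH]2)n1` has not been measured in this assay. Relative to compound 3 it shows (chloro in place of methyl on an aromatic carbon). The methyl leaves and a chloro enters at the same place, next to the ring nitrogen, so the size and shape of the molecule hardly change. Going by the values given here, with no measured step of this kind among the three compounds, the expected step in this assay is small, most likely none beyond the scatter, with a slight lean downward.

Compound 4 is therefore expected to give 38%, in the range 15% to 60%, an estimated step of a number 6 percentage points lower from compound 3 to compound 4 (within the scatter).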

Compound 4, a percentage reported as inhibition, in the whole organism at one dose (the size of the read-out at that dose, not a potency): 30%
The estimate for compound 4 lay 8 percentage points above the measured number, within the range that was stated.
By their numbers in this assay, from the lowest: compound 2; then compound 1; then compound 4; then compound 3.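

In this assay, for the compounds shown here, putting a chloro in place of the methyl on this aromatic carbon, next to the ring nitrogen, gives the first step that can be counted: a number 14 percentage points lower from compound 3 to compound 4 (beyond the scatter). Although each group brings a single heavy atom and neither adds a hydrogen-bond donor or acceptor, the two are not interchangeable at this place, and the methyl is the better of the two on this read-out. The methyl is not essential for a positive reading, however, since compound 4 still gives 30%, but no measurement available here offers an explanation for the lower number.

Going by these compounds, it remains open whether an amine, a methoxy group, a carboxylic acid or a longer chain such as ethyl at this same place would match the methyl, exceed it or fall below the chloro. On these data alone, it is also open whether a chloro at the places that carry the methyl in compound 1 and compound 2 would shift the number in the same direction, and how far this single step at one dose would hold at other doses.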